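Lengthening the amide: acetyl to propanoyl on compound 2

The source may report more compounds than this note shows. Statements on the series, on what has been measured and on what is new or still open speak of the compounds shown alone.

Measured so far:
compound 1 `CCC(=O)NCc1ccc(F)c(OC)c1` gives 86%
compound 2 `COc1ccc(F)c(CCCNC(C)=O)c1` gives 100%

In an assay on isolated protein for agonist activity at melatonin receptor type 1C (Xenopus laevis), read by spectrophotometry (a lower number here means a smaller maximal response, a higher number a larger maximal response), compound 2 stands highest of the two numbers; its nearest neighbour, compound 1, lies lower by a margin beyond the scatter. For the measured compounds named here, no single-change step between measured compounds exists. Compound 3 `CCC(=O)NCCCc1cc(OC)ccc1F` differs from compound 2 by methyl in place of hydrogen on a saturated chain carbon bound to a carbonyl carbon, read one bond further out as acetyl to propanoyl. Nothing measured isolates this change, so in this assay a step within the scatter is expected, leaning slightly downward if at all. Compound 3 is expected to give 93%, ranging from 78% to 105%. The expected step is a number 7 percentage points lower from compound 2 to compound 3 (within the scatter).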

Compound 3, largest response reached (reported as efficacy), in percent of the reference or control that the assay uses: 100%
Compound 3: the middle estimate sits 7 percentage points below what was measured; the range from low to high includes it.
By their numbers in this assay, from the lowest: compound 1; then compounds 2 and 3 (each within the scatter of the next).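

In this assay, for the compounds shown here, the step from acetyl to propanoyl reads no change at the digits printed from compound 2 to compound 3 (within the scatter) and is the first single-change comparison. It shows that methyl in place of hydrogen on a saturated chain carbon bound to a carbonyl carbon leaves the maximal response of the shared core intact. Nothing available explains this outcome. On these data alone, whether a longer chain such as butanoyl, or a branched group such as isopropyl, would be accommodated at this position stays open. So does whether the two compounds match in potency, since only the maximal response is shown.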